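The source may hold more compounds than are shown below. What is called first, only, known or untested is meant among the compounds shown, and "the series" means these compounds.

Compound 3 `COc1ccc(Cl)cc1C(=O)Nc1ccc(C2=NN(C)C(c3ccc([N+](=O)[O-])cc3)C2)cc1` gives 93% in a functional assay on the whole organism (strain albino) with Rattus norvegicus as the target, read by paw edema, with stated times of 1 h and 4 h, at a dose of 25 mg/kg by the oral route (on this read-out higher numbers stand for a stronger effect at the one dose given and lower numbers for a weaker effect), the second highest of the three numbers shown: compound 2 `COc1ccc(Cl)cc1C(=O)Nc1ccc(C2=NN(C)C(c3ccccc3[N+](=O)[O-])C2)cc1` gives 96.5%, a gap within the scatter, and compound 1 `COc1ccc(Cl)cc1C(=O)Nc1ccc(C(=O)/C=C/c2ccccc2[N+](=O)[O-])cc1` gives 81.8%, a gap beyond the scatter. Among the compounds with values here, the only single-point step measured, a number 3.5 percentage points lower from compound 2 to compound 3 (within the scatter), moves the nitro group and stays within the scatter. Compound 4 `COc1ccc(Cl)cc1C(=O)Nc1ccc(C2=NN(c3ccccc3)C(c3ccc([N+](=O)[O-])cc3)C2)cc1` differs from compound 3 by phenyl in place of methyl on an amine nitrogen in a ring. Within the data shown here, no measured pair exchanges the group on the ring nitrogen, so no step bears directly on this change; the nitrophenyl step shows only that a change at the saturated ring carbon left the read-out within the scatter. The expected step of a number 5 percentage points lower from compound 3 to compound 4 (within the scatter) is therefore small, with no direction claimed beyond the scatter. Compound 4 is estimated at 88%, between 70% and 98%.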

Compound 4, a percentage reported as activity, at one dose (the size of the read-out at that dose, not a potency): 90.9%
Compound 4: middle estimate off by 2.9 percentage points, on the low side; measured number inside the range.
By their numbers in this assay, from the lowest: compounds 1, 4, 3 and 2 (each within the scatter of the next, the first and the last beyond it).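

Phenyl in place of methyl on an amine nitrogen in a ring gives a number 2.1 percentage points lower from compound 3 to compound 4 (within the scatter) and is the first direct reading at this position. With the 4-nitrophenyl group held constant, this position accepts an aromatic ring in place of a single carbon without a change beyond the scatter. No available evidence bears on why the read-out stays within the scatter. Left open is whether a carboxylic acid or an amine on a longer chain at this nitrogen would also stay within the scatter. Also open, from the compounds shown here alone, is whether phenyl here gives the same reading alongside the 2-nitrophenyl group.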